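Chloro for Fluoro on the Indole Core of Compound 1

The compounds below may be only part of what the source reports. "The series", "measured", "known", "first", "only" and "open" are said of these compounds alone.

Compound 1 `O=C(O)/C(S)=C/c1c[nH]c2c(F)cccc12` is examined in an assay on isolated protein for inhibition of Calpain-1 catalytic subunit (Sus scrofa) (on this read-out lower numbers stand for stronger inhibition and higher numbers for weaker inhibition), where compound 1 gives 110 nM. Its companion compound 2 `O=C(O)/C(S)=C/c1c[nH]c2cc(F)ccc12` carries its fluoro at a different carbon of the shared core, and in this assay compound 2 gives 300 nM. Among the measured compounds shown here, of the two numbers known, compound 1 stands lowest, and the gap to compound 2 lies beyond the usual scatter, so compound 1 is the stronger inhibitor of this pair.

The next compound, compound 3 `O=C(O)/C(S)=C/c1c[nH]c2c(Cl)cccc12`, differs from compound 1 in one place: chloro in place of fluoro on an aromatic carbon. For the measured compounds named here, no comparable exchange of one halogen for another has been measured in this set, so there is no measured step to lean on. The change keeps the count of heavy atoms, donors, acceptors and charge unchanged, and the step from compound 1 to compound 3 is expected to be small, no change at the digits printed from compound 1 to compound 3 (within the scatter), most likely within the scatter in either direction. On this basis compound 3 is estimated at 110 nM in this assay, with a range from 40 nM to 300 nM.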

Compound 3, half-maximal inhibitory concentration: 90 nM
Beside the measured number, compound 3's estimate is 1.2-fold (0.09 log units) above it; low and high end bracket the measured number.
By their numbers in this assay, from the lowest: compounds 3 and 1 (each within the scatter of the next); then compound 2.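

In this assay, chloro in place of fluoro on this aromatic carbon, ortho to a fused ring, gives a 1.2-fold lower number from compound 1 to compound 3 (0.09 log units; within the scatter) and so leaves the read-out unresolved between the two halogens. Among the compounds shown here, the earlier pair showed only that the placement of fluoro on the shared core separates compound 1 from compound 2, whereas this step is the first to exchange the group itself while its place stays fixed, and it shows that this carbon can carry either fluoro or chloro with no difference beyond the scatter. Nothing among the available findings explains why the two halogens read alike here.

The compounds shown leave open whether this tolerance extends beyond these two halogens, since bromo, methoxy, an amine or a plain hydrogen on the same carbon would test whether any group is needed there and how much its nature matters. They also leave open whether chloro would read the same on the carbon that carries fluoro in compound 2, so the exchange is known at one place on the core only.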